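Swapping Pentyl for Cyclohexyl on the Shared Core

The compounds below may be only part of what the source reports. "The series", "measured", "known", "first", "only" and "open" are said of these compounds alone.

Compound 1, `CCCCCCc1nc(N)n(CC(=O)Nc2ccccc2)c1-c1ccccc1Br`, gives 8600 nM in a functional assay on MIA PaCa-2 cells (Homo sapiens) for antiproliferative activity, read by MTT assay, with a stated time of 48 h; a lower number here means a stronger inhibitor, a higher number a weaker inhibitor.
Compound 2, `CC(C)(C)c1ccc(Cc2nc(N)n(CC(=O)Nc3ccccc3)c2-c2ccccc2Br)cc1`, gives 4900 nM.
Compound 3, `CCCCCCc1nc(N)n(CC(=O)Nc2ccc(C)cc2)c1-c1ccccc1Br`, gives 6500 nM.

Compound 3 stands second highest of the three numbers; the step of a 1.3-fold lower number from compound 1 to compound 3 (0.12 log units; within the scatter) is small, and compound 2 sits close as well. Compound 4, `Cc1ccc(NC(=O)Cn2c(N)nc(CC3CCCCC3)c2-c2ccccc2Br)cc1`, differs from compound 3 in one place: cyclohexyl in place of pentyl on a saturated chain carbon bound to an aromatic carbon. Going by the values given here, the only measured step touching that same position is a 1.8-fold lower number from compound 1 to compound 2 (0.24 log units; within the scatter), where a ring-bearing group replaced pentyl and the number barely moved. With a six-membered ring of carbon now entering at that same saturated chain carbon, the expected step of a 1.3-fold lower number from compound 3 to compound 4 (0.11 log units; within the scatter) is likewise small, within the usual scatter, in this assay. Compound 4 is therefore estimated at 5000 nM, in a range from 2000 nM to 14000 nM.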

Compound 4, half-maximal inhibitory concentration: 48800 nM
Estimate against measurement, compound 4: 9.8-fold (0.99 log units) below, outside the stated range (above it).
By their numbers in this assay, from the lowest: compounds 2, 3 and 1 (each within the scatter of the next); then compound 4.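

Going by these compounds alone, the step of a 7.5-fold higher number from compound 3 to compound 4 (0.88 log units; beyond the scatter) is the first at this position to lie beyond the scatter, while a 1.8-fold lower number from compound 1 to compound 2 (0.24 log units; within the scatter) stayed within it. This saturated chain carbon is therefore not indifferent to what it carries, and a ring entering here does not always leave the number in place. Nothing measured here explains the change.

Still open, going by these compounds, is how a smaller cyclopentyl ring, a plain phenyl ring or a chain longer than pentyl would read at this same carbon on the core of compound 3.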